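The source may hold more compounds than are shown below. What is called first, only, known or untested is meant among the compounds shown, and "the series" means these compounds.

Of the compounds shown here, three measured so far share one core and differ only in the group carried on the methylated amine. Compound 1 `CN(Cc1ccc(Oc2ccccc2)cc1)Cc1cn(C)c2ccc(CNc3ccc(F)cc3)cc12` carries a phenoxy group there, and in a functional assay on MCF7 cells (Homo sapiens) for antiproliferative activity, read by MTT assay, with a stated time of 72 h (on this read-out lower numbers stand for stronger inhibition and higher numbers for weaker inhibition), compound 1 gives 37000 nM. Compound 2 `CN(Cc1ccc(-c2ccccc2)cc1)Cc1cn(C)c2ccc(CNc3ccc(F)cc3)cc12` carries a phenyl group, and in this assay compound 2 gives 20200 nM. Compound 3 `CN(Cc1cccc2ccccc12)Cc1cn(C)c2ccc(CNc3ccc(F)cc3)cc12` carries a naphthyl group, and in this assay compound 3 gives 4550 nM. Within the data shown here, the one step between neighbours is a 1.8-fold lower number from compound 1 to compound 2 (0.26 log units; within the scatter). On these numbers compound 2 stands second highest of three: compound 1 sits within the scatter of it, while compound 3 gives a lower number that lies beyond the scatter.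

Compound 4 `CN(Cc1ccc(-c2ccccc2)cc1)Cc1cn(C)c2ccc(C(=O)Nc3ccc(F)cc3)cc12` is not yet measured. It differs from compound 2 by (4-fluorophenyl)carbamoyl in place of ((4-fluorophenyl)amino)methyl on an aromatic carbon. Among the measured compounds shown here, none of the measured steps bears on this change: the only step, from compound 1 to compound 2, alters a different part of the molecule, and no measured pair alters the link to the fluorophenyl group. The expectation for compound 4 therefore rests on compound 2 alone, with a wide range. In this assay compound 4 is estimated at 20000 nM, between 4000 nM and 100000 nM. The step this estimate implies, a 1.0-fold lower number from compound 2 to compound 4 (0.00 log units; within the scatter), is expected to stay within the scatter.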

Compound 4, half-maximal inhibitory concentration: 54400 nM
Compound 4: middle estimate off by 2.7-fold (0.43 log units), on the low side; low and high end bracket the measured number.
By their numbers in this assay, from the lowest: compound 3; then compounds 2, 1 and 4 (each within the scatter of the next, the first and the last beyond it).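

In this assay, among these compounds, the change of ((4-fluorophenyl)amino)methyl to (4-fluorophenyl)carbamoyl gives a 2.7-fold higher number from compound 2 to compound 4 (0.43 log units; beyond the scatter) and so counts as a modest step, which shows that the link joining the fluorophenyl ring to the shared core has a bearing on the read-out, whereas the earlier compounds varied only the group on the methylated amine. The two groups have the same counts of hydrogen-bond donors and acceptors, and each carries one six-membered aromatic ring, so those counts do not separate them, and the visible difference is the carbonyl that enters with the amide. Nothing measured here offers an explanation for this step.

The compounds shown leave open whether the same change of link would give a similar step with the naphthyl group of compound 3 or the phenoxy group of compound 1 on the methylated amine. They also leave open how other links at this position would compare, such as a sulfonamide, an ether or a longer chain, and whether the fluorine could give way to chlorine or a methoxy group.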